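The source may hold more compounds than are shown below. What is called first, only, known or untested is meant among the compounds shown, and "the series" means these compounds.

The measured compounds and their values:

Compound 1 `NS(=O)(=O)Oc1ccc2c(c1)CN(C(=O)c1ccc(N3CCC(N4CCCCC4)CC3)cc1)CC2` gives 8.5%.
Compound 2 `CCN(Cc1cccc(Br)c1)c1cccc(C(=O)N2CCc3ccc(OS(N)(=O)=O)cc3C2)c1` gives 20.9%.
Compound 3 `CN(C)CCN(Cc1ccccc1)c1ccc(C(=O)N2CCc3ccc(OS(N)(=O)=O)cc3C2)cc1` gives 13.9%.

In an assay on HEK293 cells for inhibition of Steryl-sulfatase (Homo sapiens), tested at 0.1 uM (a lower number here means a weaker effect, a higher number a stronger effect of the compound at the concentration tested), compound 2 stands at the highest of the three numbers. Compound 3 sits within the usual scatter of compound 2, so the two cannot be told apart, while compound 1 lies beyond the scatter below compound 2. Compound 4 `CCN(Cc1ccncc1)c1cccc(C(=O)N2CCc3ccc(OS(N)(=O)=O)cc3C2)c1` differs from compound 2 in one place: pyridin-4-yl in place of 3-bromophenyl on a saturated chain carbon bound to a nitrogen on an aromatic ring. Among the measured compounds shown here, no step between measured compounds matches this change, so there is nothing to lean on. The step from compound 2 to compound 4 is expected to be small, a number 5.9 percentage points lower from compound 2 to compound 4 (within the scatter), pointing slightly downward but most likely staying within the scatter. Compound 4 is therefore expected to give about 15%, between 4% and 28%.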

Compound 4, a percentage reported as inhibition, at one concentration (the size of the read-out at that concentration, not a potency): 33.3%
Estimate against measurement, compound 4: 18.3 percentage points below, outside the stated range (above it).
By their numbers in this assay, from the lowest: compounds 1, 3 and 2 (each within the scatter of the next, the first and the last beyond it); then compound 4.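

In this assay, among the compounds shown here, the change to pyridin-4-yl on this saturated chain carbon gives a number 12.4 percentage points higher from compound 2 to compound 4 (beyond the scatter) and is the first single change in this set that can be read. It shows that this position responds to the choice of ring and that the effect at this concentration does not depend on keeping the bromine. Nothing measured here explains the rise.

The change removes the bromine and adds a ring nitrogen at once, so their contributions remain unseparated. A plain phenyl ring or pyridin-3-yl at this place would help to tell them apart.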